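A few compounds are considered here, and "the series" means these few. Any claim that something is new, unique, unknown or untested is made for them only; others in the source may bear on it.

Compound 3 `Fc1ccc(N2CCN(Cc3ccn4c(CC5CC5)nnc4c3C(F)(F)F)CC2)c(Cl)c1` belongs to a small set of three close analogues examined in a functional assay on HEK293 cells for agonist activity at metabotropic glutamate receptor 8 (Homo sapiens), read by a luciferase reporter and cAMP accumulation; on this read-out lower numbers stand for an effect already at smaller amounts and higher numbers for an effect only at larger amounts of compound. In this assay compound 3 gives > 10000 nM, which is a limit of the assay and not a number. Compound 1 `Fc1cc(Cl)ccc1N1CCN(Cc2ccn3c(CC4CC4)nnc3c2C(F)(F)F)CC1` gives > 10000 nM in this assay, again a limit. Compound 2 `Fc1ccc(N2CCN(Cc3cc(C(F)(F)F)cn4c(CC5CC5)nnc34)CC2)c(F)c1` gives > 10000 nM, also a limit. Within the data shown here, the single one-point step measured so far, a step that the two limits leave unreadable from compound 1 to compound 3, stays unreadable because of the limit of > 10000 nM in this assay, at which 3 of the 3 values shown sit. Compound 4 `Fc1ccccc1N1CCN(Cc2ccn3c(CC4CC4)nnc3c2C(F)(F)F)CC1` differs from compound 3 by 2-fluorophenyl in place of 2-chloro-4-fluorophenyl on an amine nitrogen in a ring. No readable step bears on this change, so neither size nor direction can be taken from the data. Compound 4 is therefore expected to give 15000 nM in this assay, with a range of 3000 nM to 60000 nM, which means an expected step that the limit leaves unreadable from compound 3 to compound 4.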

Compound 4, half-maximal effective concentration: > 10000 nM
Compound 4 was reported as a limit (the forecaster's own chance of this, stated with the estimate: 85%); the middle value lies beyond the limit too.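

Neither the step from compound 3 to compound 4 nor the step from compound 1 to compound 4 can be read, because both ends of each are limits: the limit of > 10000 nM in this assay, at which 4 of the 4 values shown sit.

The compounds shown leave open whether these changes on the phenyl group alter the read-out at all, and by how much.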